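The source may hold more compounds than are shown below. What is called first, only, known or untested is meant among the compounds shown, and "the series" means these compounds.

Measured so far:
compound 1 `CCN(CCNC(=O)c1cc(Cl)c(N)cc1OC)Cc1cccc(OC)c1`: 1 mg/kg
compound 2 `CCN(CCNC(=O)c1cc(Cl)c(N)cc1OC)Cc1cccc(Cl)c1`: 0.58 mg/kg

In a functional assay on the whole organism with Rattus norvegicus as the target (on this read-out lower numbers stand for an effect already at smaller amounts and higher numbers for an effect only at larger amounts of compound), compound 2 gives 0.58 mg/kg. Going by the values given here, the only other measured compound, compound 1, cannot be told apart from it on these numbers. Compound 3 `CCN(CCNC(=O)c1cc(Cl)c(N)cc1OC)Cc1ccc(Cl)cc1Cl` has not been measured yet. It differs from compound 2 in one place: 2,4-dichlorophenyl in place of 3-chlorophenyl on a saturated chain carbon bound to an amine nitrogen. Here 2,4-dichlorophenyl stands in place of 3-chlorophenyl on a saturated chain carbon bound to an amine nitrogen. Among the compounds with values here, the one measured step that bears on this is chloro in place of methoxy on an aromatic carbon, and it came out as a 1.7-fold lower number from compound 1 to compound 2 (0.24 log units; within the scatter). Within the data shown here, no measured compound carries the 2,4-dichlorophenyl group, so this evidence is thin. No step beyond the scatter is therefore expected in this assay. The expected change is a 1.2-fold higher number from compound 2 to compound 3 (0.08 log units; within the scatter). Compound 3 is estimated at 0.7 mg/kg, with an expected range of 0.2 mg/kg to 2.5 mg/kg.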

Compound 3, dose for half-maximal effect: 10 mg/kg
Compound 3: the middle estimate sits 14-fold (1.15 log units) below what was measured; measured number outside the range, above it.
By their numbers in this assay, from the lowest: compounds 2 and 1 (each within the scatter of the next); then compound 3.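

In this assay the aromatic group on this saturated chain carbon bound to an amine nitrogen clearly matters: 2,4-dichlorophenyl in place of 3-chlorophenyl gives a 17-fold higher number from compound 2 to compound 3 (1.24 log units; beyond the scatter) and so moves the number well beyond the scatter, which the earlier chloro-for-methoxy exchange did not do. The same group in place of 3-methoxyphenyl gives a 10-fold higher number from compound 1 to compound 3 (1.00 log units; beyond the scatter) in the same direction, so the rise appears against both earlier groups. Chlorine on this ring therefore does not by itself keep the number low, since compound 2 and compound 3 both carry it.

Nothing measured here explains this step. Still open, as far as these compounds go, is whether the rise follows from the added chlorine or from where the chlorines sit, which 2-chlorophenyl and 4-chlorophenyl groups on the same carbon could help separate.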